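The source may report more compounds than this note shows. Statements on the series, on what has been measured and on what is new or still open speak of the compounds shown alone.

Of the compounds shown here, two have so far been measured in a functional assay on A375P cells (Homo sapiens) for antiproliferative activity, read by MTT assay, with a stated time of 48 h; a higher number here means a weaker inhibitor, a lower number a stronger inhibitor. Compound 1 `CC(=O)Nc1cccc2c(-c3cc(NC(=O)c4ccc5c(c4)OCCO5)ccc3C)ccnc12` gives 250 nM. Compound 2 `Nc1cccc2c(-c3cccc(NC(=O)Nc4ccc(Cl)c(C(F)(F)F)c4)c3)ccnc12` gives 3000 nM, the higher of the two numbers, and compound 1 sits well below it; that gap lies beyond the usual scatter of repeated measurements. Compound 2 and compound 1 differ from each other in more than one place, so the gap cannot be pinned on any single change. Compound 3 `CC(=O)Nc1cccc2c(-c3cccc(NC(=O)Nc4ccc(Cl)c(C(F)(F)F)c4)c3)ccnc12` is compound 2 with one alteration: acetyl in place of hydrogen on a nitrogen on an aromatic ring. For the measured compounds named here, compound 1 carries the same acetamido group on the shared core, and in this assay compound 1 is the one with the lower number, which is the only hint available here. Going by the values given here, no pair of measured compounds differs only in this way, so the expectation rests on thin ground. The step is expected to be a 2.5-fold lower number from compound 2 to compound 3 (0.40 log units; beyond the scatter), toward a lower number, though a result within the scatter would not surprise. In this assay compound 3 is expected to give about 1200 nM, with a likely range from 350 nM to 4000 nM.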

Compound 3, half-maximal inhibitory concentration: 2500 nM
Beside the measured number, compound 3's estimate is 2.1-fold (0.32 log units) below it, within the range that was stated.
By their numbers in this assay, from the lowest: compound 1; then compounds 3 and 2 (each within the scatter of the next).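

In this assay, the change from amino to acetamido on the shared core, with everything else held fixed, gives a 1.2-fold lower number from compound 2 to compound 3 (0.08 log units; within the scatter). For the compounds shown here, this is the first direct reading of this change at this place, and it shows that, in this setting, a hydrogen and an acetyl on the nitrogen cannot be told apart by this measurement; the acetamido group shared by compound 1 and compound 3 therefore gives no support to the earlier hint, and since those two compounds differ in more than one place, what sets compound 1 apart cannot be read from them. Nothing measured here offers an explanation for this flat result.

It remains open whether the same change would also have so little effect on the rest of compound 1, since the amino counterpart of compound 1 is not among the compounds shown. Also open, from the compounds shown here alone, is how this place responds to other groups on the nitrogen, such as a longer acyl chain like propionyl, a methanesulfonyl or a simple methyl.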